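A few compounds are considered here, and "the series" means these few. Any claim that something is new, unique, unknown or untested is made for them only; others in the source may bear on it.

Measured so far:
- compound 1 `O=C(O)c1ccc2c(O)c(C(=O)O)cnc2c1`, in an assay on isolated protein with malate dehydrogenase, cytoplasmic (Sus scrofa) as the target (a higher number here means a weaker inhibitor, a lower number a stronger inhibitor), compound 1 gives 1290000 nM
- compound 2 `O=C(O)c1cnc2cc(O)ccc2c1O`, in this assay compound 2 gives 955000 nM

Compound 2 sits alongside compound 1 within the scatter: a 1.4-fold lower number from compound 1 to compound 2 (0.13 log units; within the scatter). Compound 3 `CC(=O)c1ccc2c(O)c(C(=O)O)cnc2c1` carries the change (acetyl in place of hydroxy on an aromatic carbon). Among the compounds with values here, no measured step covers an acetyl; the only step on this ring carbon, carboxy to hydroxy, stayed within the scatter, so nothing points to a shift beyond it here either. For compound 3 in this assay the expected step is a 1.0-fold higher number from compound 2 to compound 3 (0.02 log units; within the scatter), and the estimate for compound 3 is 1000000 nM, within 300000 nM to 3500000 nM.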

Compound 3, half-maximal inhibitory concentration: 912000 nM
Compound 3: middle estimate off by 1.1-fold (0.04 log units), on the high side; low and high end bracket the measured number.
By their numbers in this assay, from the lowest: compounds 3, 2 and 1 (each within the scatter of the next).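

In this assay, acetyl on this aromatic carbon gives no shift beyond the scatter relative to hydroxy (a 1.0-fold lower number from compound 2 to compound 3 (0.02 log units; within the scatter)), even with more heavy atoms and no hydrogen-bond donor in the entering group. The carbonyl at this position also accepts methyl in place of its hydroxy (a 1.4-fold lower number from compound 1 to compound 3 (0.15 log units; within the scatter)), so all three groups here read alike. No evidence bears on this result.

As far as these compounds go, whether an amine or a longer chain on this carbon would move the number beyond the scatter stays open. From the compounds shown here alone, the contribution of the carboxylic acid and hydroxy kept on the shared core also stays open.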